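Cyclobutyl carboxamide replacing a cyclohexyl amide against PKC delta

The source may hold more compounds than are shown below. What is called first, only, known or untested is meant among the compounds shown, and "the series" means these compounds.

Compound 1 `CO[C@H]1CC[C@@H](Nc2cc(NCc3cnccc3C(F)(F)F)ncc2C#N)CC1` gives 5000 nM in an assay on isolated protein for inhibition of protein kinase C delta type (Homo sapiens), read by TR-FRET, with a stated time of 2 h; on this read-out higher numbers stand for weaker inhibition and lower numbers for stronger inhibition. Compound 2 `N#Cc1cnc(NCc2cnccc2C(F)(F)F)cc1NC[C@H]1CC[C@@H](O)CC1` gives 500 nM. Compound 3 `CNC(=O)[C@H]1CC[C@@H](Nc2cc(NCc3cnccc3C(F)(F)F)ncc2C#N)CC1` gives 1600 nM.

Compound 3 thus stands second highest of the three numbers, between compound 1 and compound 2. For the measured compounds named here, the steps so far are a 10-fold lower number from compound 1 to compound 2 (1.00 log units; beyond the scatter), a 3.1-fold lower number from compound 1 to compound 3 (0.49 log units; beyond the scatter) and a 3.2-fold higher number from compound 2 to compound 3 (0.51 log units; beyond the scatter), all modest, all on the same attachment point. Compound 4 `CC1(C)[C@H](Nc2cc(NCc3cnccc3C(F)(F)F)ncc2C#N)C[C@H]1C(N)=O` differs from compound 3 in one place: 3-carbamoyl-2,2-dimethylcyclobutyl in place of 4-(methylcarbamoyl)cyclohexyl on a nitrogen on an aromatic ring. Going by the values given here, no measured step swaps one ring for another of a different size, so the neighbouring amide-bearing cases are the only guide; the team expects a step of similar modest size, direction uncertain, a 1.6-fold lower number from compound 3 to compound 4 (0.20 log units; within the scatter). Compound 4 is therefore estimated at 1000 nM, within 300 nM to 5000 nM.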

Compound 4, half-maximal inhibitory concentration: 900 nM
For compound 4 the middle estimate is 1.1-fold (0.05 log units) above the measured one, within the range that was stated.
By their numbers in this assay, from the lowest: compounds 2, 4 and 3 (each within the scatter of the next, the first and the last beyond it); then compound 1.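

On a nitrogen on an aromatic ring, a four-membered ring carrying an amide is tolerated in place of a six-membered one: a 1.8-fold lower number from compound 3 to compound 4 (0.25 log units; within the scatter) is the step in this assay, and a 1.8-fold higher number from compound 2 to compound 4 (0.26 log units; within the scatter) is the step from the hydroxy compound. For the compounds shown here, only the step of a 5.6-fold lower number from compound 1 to compound 4 (0.74 log units; beyond the scatter) from the methoxy compound separates the new group from an earlier one. Nothing available accounts for these numbers.

Ring size, the two ring methyl groups and the amide methyl all change together, so their shares cannot be told apart. On these data alone, how a carboxylic acid or an amine would fare in place of the carbamoyl on the cyclobutyl ring remains open.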